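Isopropyl on the outer ring of a fluorophenoxyacetic acid series

A few compounds are considered here, and "the series" means these few. Any claim that something is new, unique, unknown or untested is made for them only; others in the source may bear on it.

Compound 1 `O=C(O)COc1ccc(NC(=O)COc2ccccc2)cc1F` is the unsubstituted parent of this set. For the measured compounds named here, in a functional assay on CHO cells for agonist activity at Free fatty acid receptor 1 (Homo sapiens), read by FLIPR, tested at 100 nM (a higher number here means a stronger effect of the compound at the concentration tested, a lower number a weaker effect), compound 1 gives 29.8%, the lowest of the two numbers measured so far. Compound 2 `CC(C)c1cccc(OCC(=O)Nc2ccc(OCC(=O)O)c(F)c2)c1` carries an isopropyl on an aromatic carbon of the outer ring and gives 43.3% in this assay. Going by the values given here, the one measured step is a number 13.5 percentage points higher from compound 1 to compound 2 (beyond the scatter), a change that clears the scatter but is only modest in size.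

Compound 3 `CC(C)c1ccc(OCC(=O)Nc2ccc(OCC(=O)O)c(F)c2)cc1` is not yet measured. It differs from compound 1 by isopropyl in place of hydrogen on an aromatic carbon. Among the compounds with values here, the same group enters as in compound 2, though the structures show that it sits on a different aromatic carbon of the same ring, and no measured pair tells how that change of place matters. Within the data shown here, the only step that bears on the question is therefore a number 13.5 percentage points higher from compound 1 to compound 2 (beyond the scatter). On that basis a gain of similar size is expected, with a broad range to cover the unknown effect of position, so the estimate is a number 11.2 percentage points higher from compound 1 to compound 3 (beyond the scatter). Compound 3 is expected to give about 41% in this assay, in a range from 26% to 56%.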

Compound 3, a percentage reported as activity, at one concentration (the size of the read-out at that concentration, not a potency): 11.8%
The estimate for compound 3 lay 29.2 percentage points above the measured number; measured number below the stated range.
By their numbers in this assay, from the lowest: compound 3; then compound 1; then compound 2.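

The step of a number 18 percentage points lower from compound 1 to compound 3 (beyond the scatter) runs against a number 13.5 percentage points higher from compound 1 to compound 2 (beyond the scatter) even though the same isopropyl replaces the same hydrogen type on the same ring, so in this assay the sign of this change depends on which aromatic carbon carries the group. At the carbon para to a large group, isopropyl leaves the read-out at the tested concentration lower than in the unsubstituted parent, so a step measured at one carbon of this ring cannot be carried over to another. Nothing available gives a reason for the difference between the two places.

Open, on these data alone, is whether the drop at this carbon belongs to isopropyl in particular or would also appear with a smaller group such as methyl, or with a group carrying other atoms such as methoxy or chlorine. Also open, as far as these compounds go, is whether the order of compound 1, compound 2 and compound 3 would hold across a full concentration range, since a read-out at a single concentration is not a potency.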